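The compounds below may be only part of what the source reports. "The series", "measured", "known", "first", "only" and "open" are said of these compounds alone.

Compound 1 `Nc1ncnc2c1c(-c1cnc3[nH]ccc3c1)nn2CCCCCC(=O)NO`: > 150000 nM
Compound 2 `Nc1nc2cc(-c3nn(CCC(=O)NO)c4ncnc(N)c34)ccc2o1`: > 100000 nM

In a functional assay on MCF7 cells (Homo sapiens) for inhibition, read by MTT assay, with a stated time of 72 h (on this read-out lower numbers stand for stronger inhibition and higher numbers for weaker inhibition), compound 1 stands only at a limit, (the limit of > 150000 nM in this assay, at which 1 of the 2 values shown sits), with no number behind it. Compound 2 likewise stands at a limit, (the limit of > 100000 nM in this assay, at which 1 of the 2 values shown sits). Going by the values given here, with both values at limits, no step between measured compounds can be drawn. Compound 3 `CNC(=O)CCCCCCCn1nc(-c2cnc3[nH]ccc3c2)c2c(N)ncnc21` is not yet measured. It differs from compound 1 by 2-(methylcarbamoyl)ethyl in place of hydroxycarbamoyl on a saturated chain carbon, five bonds along the chain from an aromatic nitrogen. Given that compound 1 shows no measurable inhibition in this assay, the step of a number no higher from compound 1 to compound 3 (the limit leaves the size open) is expected to be none beyond the scatter, most likely another limit. The estimate for compound 3 is 150000 nM, expected between 50000 nM and 500000 nM.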

Compound 3, half-maximal inhibitory concentration: 7570 nM
The estimate for compound 3 lay 20-fold (1.30 log units) above the measured number; measured number outside the range, below it.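

With 2-(methylcarbamoyl)ethyl in place of hydroxycarbamoyl on a saturated chain carbon, five bonds along the chain from an aromatic nitrogen, this assay gives an at least 19-fold lower number from compound 1 to compound 3 (1.29 log units; beyond the scatter). Hydroxycarbamoyl is therefore not needed for a measurable number on this core and chain, and compound 3 gives 7570 nM. The step has only a lower bound, as compound 1 stands at a limit: the limit of > 150000 nM in this assay, at which 1 of the 3 values shown sits.

On these data alone, whether the lower number goes with the methylcarbamoyl end or with the added chain length stays open, as both change together. As far as these compounds go, how a carboxylic acid or an amine at that chain end would read also stays open.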